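A few compounds are considered here, and "the series" means these few. Any claim that something is new, unique, unknown or untested is made for them only; others in the source may bear on it.

Of the compounds shown here, two built on one shared core have been measured in an assay on HEK293 cells for negative allosteric modulation of metabotropic glutamate receptor 5 (Homo sapiens), read by FLIPR, with a stated time of 1 h; on this read-out lower numbers stand for stronger inhibition and higher numbers for weaker inhibition. Compound 1 `CCCCN1CCc2nc(C#Cc3ccccc3)sc2C1` carries a butyl group on the amine nitrogen in the ring; in this assay compound 1 reaches only a limit of the assay, > 10000 nM, which is the limit of > 10000 nM in this assay, at which 1 of the 2 values shown sits. Compound 2 `O=C(C1CC1)N1CCc2nc(C#Cc3ccccc3)sc2C1`, in which a cyclopropylcarbonyl stands in place of the butyl, gives in this assay 290 nM. The step of an at least 34-fold lower number from compound 1 to compound 2 (1.53 log units; beyond the scatter) is the one measured step, and compound 2 holds the only number shown in this assay, the other value being a limit. Compound 3 `CC1CC1C(=O)N1CCc2nc(C#Cc3ccccc3)sc2C1` differs from compound 2 by methyl in place of hydrogen on a saturated ring carbon: the cyclopropylcarbonyl becomes a (2-methylcyclopropyl)carbonyl. Among the measured compounds shown here, no measured step touches this kind of change; the single step, from the butyl to the cyclopropylcarbonyl on the amine nitrogen, was large but concerns a different place, so it gives no direct guide. Compound 3 is therefore expected to sit close to compound 2. The expected step, a 1.0-fold higher number from compound 2 to compound 3 (0.01 log units; within the scatter), should not go beyond the scatter. The estimate for compound 3 in this assay is 300 nM, within 120 nM to 800 nM.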

Compound 3, half-maximal inhibitory concentration: > 10000 nM
Compound 3 ended at the assay's limit; the forecaster's own chance of this, stated with the estimate: 5%; middle value at least 33-fold (1.52 log units) from the limit.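

In this assay, methyl in place of hydrogen on a saturated ring carbon of the three-membered ring gives an at least 34-fold higher number from compound 2 to compound 3 (1.53 log units; beyond the scatter), so one added carbon on the cyclopropylcarbonyl is enough to lose the measurable inhibition seen with compound 2. The earlier step had shown that exchanging the whole group on the amine nitrogen could change the read-out strongly, whereas this one shows that a small change within the cyclopropyl group can do so too. The step from compound 1 to compound 3 cannot be read, as compound 1 and compound 3 both stand at a limit rather than at a number: the limit of > 10000 nM in this assay, at which 2 of the 3 values shown sit.

The compounds shown leave open whether this loss belongs to methyl in particular or would follow from any replacement of that hydrogen, such as a fluorine atom or a hydroxymethyl group. They also leave open how the read-out responds when the three-membered ring is changed as a whole, as in a cyclobutylcarbonyl on the same amine nitrogen, and how far compound 3 lies beyond its limit.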